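This account rests on a few compounds, and the source may have more. Where it says the series, first, only, none or still open, it means among the compounds named here.

Of the compounds shown here, three sharing one core have been tested in an ADME assay on HEK293 cells (Homo sapiens) for antiproliferative activity, read by MTT assay, with a stated time of 24 h; on this read-out higher numbers stand for weaker inhibition and lower numbers for stronger inhibition. Compound 1 `COc1cc(/C=C/C(=O)c2cc(-c3cc(OC)c(OC)c(OC)c3)n3nc(-c4ccccc4)cc3n2)cc(OC)c1OC` gives 41000 nM, compound 2 `COc1ccc(-c2cc(/C=C/C(=O)c3ccc(OC)c(OC)c3)nc3cc(-c4ccccc4)nn23)cc1` gives 48500 nM, and compound 3 `COc1ccc(-c2cc(C(=O)/C=C/c3cc(OC)c(OC)c(OC)c3)nc3cc(-c4ccccc4)nn23)cc1OC` gives 46800 nM. Among these three numbers compound 3 cannot be told apart from either neighbour: compound 2 is nearest to it and compound 1 furthest, yet both gaps fall within the usual scatter of repeated measurements. Going by the values given here, the only single-point step measured so far, a 1.1-fold higher number from compound 1 to compound 3 (0.06 log units; within the scatter), likewise changed nothing beyond that scatter.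

Compound 4 `COc1ccc(-c2cc(C(=O)/C=C/c3ccc(Cl)cc3)nc3cc(-c4ccccc4)nn23)cc1OC` has not yet been measured. It differs from compound 3 in one place: 4-chlorophenyl in place of 3,4,5-trimethoxyphenyl on a double-bonded chain carbon bound to a double-bonded chain carbon. Among the compounds with values here, no measured step touches this part of the molecule in the same way, since the one step on hand removed a single methoxy elsewhere rather than exchanging a whole 3,4,5-trimethoxyphenyl for a 4-chlorophenyl. Within the data shown here, with all three measured compounds clustered so closely and the sole step flat, there is no ground to expect a move beyond the scatter in either direction; the estimated step of a 1.0-fold lower number from compound 3 to compound 4 (0.02 log units; within the scatter) is therefore expected to be small. Compound 4 is accordingly estimated at 45000 nM, with a plausible range from 18000 nM to 110000 nM.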

Compound 4, half-maximal inhibitory concentration: 39100 nM
Beside the measured number, compound 4's estimate is 1.2-fold (0.06 log units) above it; low and high end bracket the measured number.
By their numbers in this assay, from the lowest: compounds 4, 1, 3 and 2 (each within the scatter of the next).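

In this assay the exchange of 3,4,5-trimethoxyphenyl for 4-chlorophenyl on a double-bonded chain carbon bound to a double-bonded chain carbon gives a 1.2-fold lower number from compound 3 to compound 4 (0.08 log units; within the scatter) even though this is a large change in the structure. The group that leaves has 12 heavy atoms and 3 hydrogen-bond acceptors, while the group that enters has 7 heavy atoms and 0 hydrogen-bond acceptors, so the earlier single methoxy step now has a companion at a second place in the molecule, and here too a change in structure does not carry the number beyond the usual scatter. No evidence is available on what lies behind this flat result.

The compounds shown leave open whether the number at this place would stay as flat with a group of a different kind on the aromatic ring, such as an amine or a carboxylic acid, or with a longer chain in place of the ring. They also leave open whether any single change to this shared core can move the number beyond the scatter in either direction.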